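The compounds below may be only part of what the source reports. "The series", "measured", "known", "first", "only" and "open" are said of these compounds alone.

Values in an ADME assay on microsomes from liver (Mus musculus) for metabolic stability, read by LC-MS, using NADPH, with a stated time of 60 min, tested at 0.1 uM; a higher number here means that more of the compound is left, a lower number that less of the compound is left:
- compound 1 `Fc1ccc(Nc2cc3[nH]c(Nc4ccc(N5CCNCC5)cn4)nc3cn2)cc1C(F)(F)F`: 55%
- compound 2 `Fc1ccc(Nc2cc3[nH]c(Nc4cc(N5CCNCC5)ccn4)nc3cn2)cc1C(F)(F)F`: 78%
- compound 3 `O=C(c1ccnc(Nc2nc3cnc(Nc4ccc(F)c(C(F)(F)F)c4)cc3[nH]2)c1)N1CCN(C2CC2)CC1`: 93%

Of the three, compound 3 stands highest in this assay at 93%. Compound 2 is the nearest and compound 1 the furthest, both beyond the scatter.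

Compound 4 `C[C@@H]1CN(C(=O)c2ccnc(Nc3nc4cnc(Nc5ccc(F)c(C(F)(F)F)c5)cc4[nH]3)c2)C[C@H](C)N1` changes only the group on the carbonyl carbon of compound 3: 3,5-dimethylpiperazin-1-yl in place of 4-cyclopropylpiperazin-1-yl on a carbonyl carbon. The 4-cyclopropylpiperazin-1-yl leaves and 3,5-dimethylpiperazin-1-yl enters.

For the measured compounds named here, one measured step bears on this, and only indirectly: a number 15 percentage points higher from compound 2 to compound 3 (beyond the scatter). That modest step put (4-cyclopropylpiperazin-1-yl)carbonyl in place of piperazin-1-yl on an aromatic carbon. Going by the values given here, no measured pair compares two groups on the carbonyl carbon, so the size of the new step remains poorly defined. Compound 2 at 78% serves as a rough lower guide. A small downward step is expected, close to the scatter, and is estimated as a number 8 percentage points lower from compound 3 to compound 4 (within the scatter). The expected value for compound 4 is 85%, with an estimated range of 68% to 97%.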

Compound 4, percent of the compound remaining: 90%
Compound 4: the middle estimate sits 5 percentage points below what was measured; the measured number falls inside the stated range.
By their numbers in this assay, from the lowest: compound 1; then compound 2; then compounds 4 and 3 (each within the scatter of the next).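

In this assay, 3,5-dimethylpiperazin-1-yl in place of 4-cyclopropylpiperazin-1-yl on the carbonyl carbon gives a number 3 percentage points lower from compound 3 to compound 4 (within the scatter), so this position accepts the loss of the three-membered ring and the arrival of a hydrogen-bond donor and defined stereocentres with no readable change. The step to the (3,5-dimethylpiperazin-1-yl)carbonyl in place of piperazin-1-yl on an aromatic carbon gives a number 12 percentage points higher from compound 2 to compound 4 (beyond the scatter), which shows that the higher number does not depend on the cyclopropyl group. Nothing at hand explains either step.

From the compounds shown here alone, it remains open how much of that rise belongs to the carbonyl and how much to the substituents on the piperazine. Going by these compounds, an unsubstituted piperazin-1-yl or a morpholine on the carbonyl carbon would separate these, and the role of the stereocentres in the 3,5-dimethylpiperazin-1-yl also stays open.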